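The compounds below may be only part of what the source reports. "The series", "measured", "known", "first", "only" and "open" are said of these compounds alone.

The shared core appears in compound 1 `C/C(=C\COC(=O)NC(C)C)C1=CC(=O)C(C)(C)O1` and compound 2 `COc1ccc(/C=C/C=C(\C)C2=CC(=O)C(C)(C)O2)cc1`. In a functional assay on MT4 cells (Homo sapiens) for inhibition (on this read-out higher numbers stand for weaker inhibition and lower numbers for stronger inhibition), compound 1 gives 2.3 ug/mL. In this assay compound 2 gives 5.7 ug/mL, the higher of the two numbers, and the gap to compound 1 lies beyond the scatter. Compound 3 `C/C(=C\C=C\c1ccccc1)C1=CC(=O)C(C)(C)O1` differs from compound 2 by hydrogen in place of methoxy on an aromatic carbon. Among the compounds with values here, no step between measured compounds covers this change, so in this assay the expected step of a 1.1-fold lower number from compound 2 to compound 3 (0.06 log units; within the scatter) is small, of no set direction, and likely within the scatter. Compound 3 is expected to give 5 ug/mL, within a range of 2 ug/mL to 12 ug/mL.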

Compound 3, half-maximal inhibitory concentration: 6.5 ug/mL
The estimate for compound 3 lay 1.3-fold (0.11 log units) below the measured number; the measured number falls inside the stated range.
By their numbers in this assay, from the lowest: compound 1; then compounds 2 and 3 (each within the scatter of the next).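

Hydrogen in place of methoxy on an aromatic carbon, para to a large group, reads in this assay as a 1.1-fold higher number from compound 2 to compound 3 (0.06 log units; within the scatter) and so the methoxy is not required for a number of this size at this position. No measurement offered here accounts for this result.

As far as these compounds go, whether an amine or a carboxylic acid on this aromatic carbon would give a number beyond the scatter from compound 3 stays open. So does the outcome of a chlorine atom at this position.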